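Swapping a cinnamate ester arm for a nitrile

The compounds below may be only part of what the source reports. "The series", "measured", "known", "first", "only" and "open" are said of these compounds alone.

Measured compounds:
Compound 1, `CCN(CC)c1ccc2cc(C(=O)c3ccc(N4CCN(C(=O)CN5CCN(C(=O)/C=C/c6ccccc6)CC5)CC4)cc3)oc2c1`: in a functional assay on MCF7 cells (Homo sapiens) for cytotoxicity, read by MTT assay, with a stated time of 48 h (on this read-out higher numbers stand for weaker inhibition and lower numbers for stronger inhibition), compound 1 gives 13400 nM.
Compound 2, `CCN(CC)c1ccc2cc(C(=O)c3ccc(N4CCN(C(=O)CN5CCN(Cc6ccc(/C=C/C(=O)OC)cc6)CC5)CC4)cc3)oc2c1`: in this assay compound 2 gives 8730 nM.

Both compounds share a large common core and differ only in one outer arm. In this assay their two numbers sit within the usual scatter of repeated measurements of each other, so the data do not separate compound 2 from compound 1, and neither can be called the more potent.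

Compound 3, `CCN(CC)c1ccc2cc(C(=O)c3ccc(N4CCN(C(=O)CN5CCN(Cc6ccc(C#N)cc6)CC5)CC4)cc3)oc2c1`, has not yet been measured. It differs from compound 2 in a single place: cyano in place of 2-(methoxycarbonyl)ethenyl on an aromatic carbon. Among the compounds with values here, no measured pair here shows what such a swap does on this core, so there is no step to lean on. Within the data shown here, with only two numbers, both close together, the step from compound 2 to compound 3 is expected to be a 1.1-fold higher number from compound 2 to compound 3 (0.06 log units; within the scatter), with no firm reason to expect it to pass beyond the scatter in either direction. Compound 3 is therefore expected to come out near 10000 nM, within a range from 4000 nM to 25000 nM.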

Compound 3, half-maximal inhibitory concentration: > 40000 nM
Compound 3: no number, only a limit; the forecaster's own chance of this, stated with the estimate: 10%; middle value at least 4.0-fold (0.60 log units) away from the limit.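

Putting cyano in place of 2-(methoxycarbonyl)ethenyl, on an aromatic carbon para to a large group, gives an at least 4.5-fold higher number from compound 2 to compound 3 (0.66 log units; beyond the scatter) in this assay, so what sits at this position matters for the read-out, which compounds 1 and 2 alone could not show. Exchanging the whole arm on the ring amine nitrogen, 4-cyanobenzyl in place of (2-phenylethenyl)carbonyl, gives an at least 2.9-fold higher number from compound 1 to compound 3 (0.47 log units; beyond the scatter). Compound 3 reaches only a limit of the assay and not a number, so both steps give a minimum size and no exact one: the limit of > 40000 nM in this assay, at which 1 of the 3 values shown sits.

As far as these compounds go, how far compound 3 truly lies from the other two stays open, as does whether the nitrile itself or the shorter group decides the result. From the compounds shown here alone, whether a carboxylic acid at the end of the ethenyl chain, or a methyl ester set directly on the ring, would keep the level of compound 2 also stays open.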